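Swapping the five-membered ring on the benzylic carbon

The source may hold more compounds than are shown below. What is called first, only, known or untested is meant among the compounds shown, and "the series" means these compounds.

The series shares a diaryl ether scaffold carrying two chlorine atoms, with a five-membered heteroaromatic ring attached to a saturated chain carbon bound to an aromatic carbon. Compound 1 `S=c1[nH]nc(Cc2ccc(Cl)cc2Oc2ccccc2Cl)[nH]1` gives 159% in a functional assay on the whole organism (strain NMRI) with Mus musculus as the target, with a stated time of 60 min, at a dose of 20 mg/kg by the intraperitoneal route; a higher number here means a stronger effect of the compound at the dose given, a lower number a weaker effect. For the measured compounds named here, compound 2 `CCSc1nnc(Cc2ccc(Cl)cc2Oc2ccccc2Cl)[nH]1` gives 174% in this assay, which is the higher of the two numbers measured so far; the only measured step, a number 15 percentage points higher from compound 1 to compound 2 (beyond the scatter), is modest.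

Compound 3 `Nc1nnc(Cc2ccc(Cl)cc2Oc2ccccc2Cl)o1` has not yet been measured. Relative to compound 2 it differs in this way: a group of 6 heavy atoms (2 carbon, 3 nitrogen, 1 oxygen; one five-membered aromatic ring with 3 hetero atoms) in place of a group of 8 heavy atoms (4 carbon, 3 nitrogen, 1 sulfur; one five-membered aromatic ring with 3 hetero atoms), on a saturated chain carbon bound to an aromatic carbon. Going by the values given here, no measured step changes the ring itself in this manner, since the single step known only alters what sits on the sulfur of the same ring. That step is therefore only a weak guide, and it suggests the whole ring position tolerates variation without a large swing.

Compound 3 is therefore expected to land near the measured pair, with an estimated 160% and a range from 120% to 200% in this assay. The expected step of a number 14 percentage points lower from compound 2 to compound 3 (beyond the scatter) is within the scatter.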

Compound 3, a percentage reported as activity, at one dose (the size of the read-out at that dose, not a potency): 170%
Estimate against measurement, compound 3: 10 percentage points below; the measured number falls inside the stated range.
By their numbers in this assay, from the lowest: compound 1; then compounds 3 and 2 (each within the scatter of the next).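

Putting the 5-amino-1,3,4-oxadiazol-2-yl group on the saturated chain carbon bound to an aromatic carbon gives in this assay a number 4 percentage points lower from compound 2 to compound 3 (within the scatter) and so shows that this place accepts an exchange of the whole ring, not only a change on the sulfur, with no difference from compound 2 beyond the scatter. The step from the other compound of the same heavy-atom count reads a number 11 percentage points higher from compound 1 to compound 3 (beyond the scatter) and leaves compound 1 as the only one of the three set apart, since compounds 2 and 3 each stand beyond the scatter from it but not from each other, even though they share little in the ring substituent beyond the count of ring nitrogens and the ring size. Nothing available gives a reason for these numbers.

The compounds shown leave open whether a five-membered aromatic ring is needed here at all, which a carboxylic acid or a simple amine on the same chain carbon would test. They also leave open how a longer chain than ethyl on the sulfur, such as butyl, would read at this one dose.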